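From a methylfuran to a cyclohexyl group

This account rests on a few compounds, and the source may have more. Where it says the series, first, only, none or still open, it means among the compounds named here.

In an ADME assay on L6 cells (Rattus norvegicus) for cytotoxicity, read by resazurin assay, with a stated time of 72 h (a higher number here means a weaker inhibitor, a lower number a stronger inhibitor), compound 1 `CCc1ccc(C(=O)NC(=O)c2ccccc2O)cc1` reads 70 ug/mL while compound 2 `Cc1occc1C(=O)NC(=O)c1ccccc1O` reads 16 ug/mL and so holds the lower number, a gap beyond the scatter. Compound 3 `O=C(NC(=O)C1CCCCC1)c1ccccc1O` carries cyclohexyl in place of 2-methylfuran-3-yl on a carbonyl carbon and has not yet been measured. For the measured compounds named here, no measured pair shows this change directly. Compound 1 at 70 ug/mL also lacks the 2-methylfuran-3-yl group, so a moderate rise beyond the scatter is expected. The expected step runs a 2.5-fold higher number from compound 2 to compound 3 (0.40 log units; beyond the scatter) in this assay as a rough guess. Compound 3 is estimated at 40 ug/mL with an expected range of 15 ug/mL to 90 ug/mL.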

Compound 3, half-maximal inhibitory concentration: 55 ug/mL
Compound 3: middle estimate off by 1.4-fold (0.14 log units), on the low side; measured number inside the range.
By their numbers in this assay, from the lowest: compound 2; then compounds 3 and 1 (each within the scatter of the next).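

In this assay, for the compounds shown here, cyclohexyl in place of 2-methylfuran-3-yl on the carbonyl carbon gives a 3.4-fold higher number from compound 2 to compound 3 (0.54 log units; beyond the scatter), a direct reading of this change that the earlier compounds did not offer. Both groups have the same number of heavy atoms, so the step does not come with a change in that count. Nothing measured here explains the step.

From the compounds shown here alone, it remains open whether the aromatic ring or the ring oxygen of the departing group matters more. Plain phenyl and tetrahydropyranyl groups on this carbonyl carbon would help separate the two.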